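The source may report more compounds than this note shows. Statements on the series, on what has been measured and on what is new or still open speak of the compounds shown alone.

Of the compounds shown here, three of a shared core have been measured in an assay (Cricetulus griseus) for inhibition of aldehyde dehydrogenase, mitochondrial (Homo sapiens); a lower number here means a stronger inhibitor, a higher number a weaker inhibitor. Compound 1, `CCOC(=O)CCCCCOc1ccc2c(=O)c(-c3ccc(O)cc3)coc2c1`, gives 280 nM. Compound 2, `NCCCCOc1ccc2c(=O)c(-c3ccc(O)cc3)coc2c1`, gives 250 nM. Compound 3, `CCCCCCC(Oc1ccc2c(=O)c(-c3ccc(O)cc3)coc2c1)C(=O)OCC`, gives 7200 nM. Among these, compound 1 stands second highest: the step of a 1.1-fold lower number from compound 1 to compound 2 (0.05 log units; within the scatter) lies within the scatter, while compound 3 shows a much higher number than compound 1, which means a weaker inhibitor.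

Compound 4, `C=CCOc1ccc2c(=O)c(-c3ccc(O)cc3)coc2c1`, has not yet been measured. Compared with compound 1, the change is vinyl in place of 4-(ethoxycarbonyl)butyl on a saturated chain carbon bound to an oxygen on an aromatic ring.

For the measured compounds named here, only one measured step bears on this. The step from compound 1 to compound 2 exchanged amino for (ethoxycarbonyl)methyl on a saturated chain carbon, four bonds along the chain from an oxygen on an aromatic ring, and it changed nothing beyond the scatter. Going by the values given here, the change to compound 4 is of a different kind, since it sits on a saturated chain carbon bound to an oxygen on an aromatic ring and removes most of the chain; no measured step tests this. Compound 3 differs from compound 1 in more than one place, so it gives no direct guide.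

For compound 4 in this assay, the expected step is a 1.6-fold higher number from compound 1 to compound 4 (0.21 log units; within the scatter), a modest weakening. The estimated value for compound 4 is 450 nM, within a range from 130 nM to 1500 nM.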

Compound 4, half-maximal inhibitory concentration: 180 nM
Compound 4: middle estimate off by 2.5-fold (0.40 log units), on the high side, within the range that was stated.
By their numbers in this assay, from the lowest: compounds 4, 2 and 1 (each within the scatter of the next); then compound 3.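

In this assay, vinyl takes the place of 4-(ethoxycarbonyl)butyl on a saturated chain carbon bound to an oxygen on an aromatic ring, so a group of 9 heavy atoms gives way to one of 2, yet the result stays within the scatter (a 1.6-fold lower number from compound 1 to compound 4 (0.19 log units; within the scatter)). Setting vinyl against 3-aminopropyl at the same place gives the same picture (a 1.4-fold lower number from compound 2 to compound 4 (0.14 log units; within the scatter)), so across compound 1, compound 2 and compound 4, neither the long ester-bearing chain nor the amino-bearing chain is needed to keep the number in this range. No measurement shown here explains why these three compounds sit so close together.

On these data alone, it remains open whether a carboxylic acid at the end of the chain, or a saturated propyl group in place of vinyl, would also stay within the scatter. Compound 3 gives a much weaker result (7200 nM), but it differs from compound 1 in more than one place, so the compounds shown cannot say which of those differences matters.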